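A few compounds are considered here, and "the series" means these few. Any claim that something is new, unique, unknown or untested is made for them only; others in the source may bear on it.

In a functional assay on A549 cells (Homo sapiens) for inhibition, read by sulforhodamine B assay, with a stated time of 48 h, tested at 50 uM (a lower number here means less inhibition of growth, a higher number more inhibition of growth at the concentration tested), compound 1 `COc1ccc([C@@H]2C/C(=N/OCc3cn(-c4ccc(O)cc4)nn3)c3cc(CC=C(C)C)c(OC)cc3O2)cc1` gives 52% and compound 3 `COc1cc2c(cc1CC=C(C)C)[C@H](O)C[C@@H](c1ccc(O)cc1)O2` gives 48% with these two values within the scatter of each other. Compound 2 `COc1cc2c(cc1CC=C(C)C)C(=O)C[C@@H](c1ccc(Oc3ccc(F)cc3)cc1)O2` gives 27% which lies beyond the scatter under the value of compound 1. Compound 1 therefore stands level with compound 3 and clear of compound 2.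

Compound 4 `COc1ccc([C@@H]2C/C(=N/OCc3cn(-c4ccc(C(N)=O)cc4)nn3)c3cc(CC=C(C)C)c(OC)cc3O2)cc1` keeps the rest of compound 1 and carries carbamoyl in place of hydroxy on an aromatic carbon, para to a large group. This is the change from 4-hydroxyphenyl to 4-carbamoylphenyl carbamoyl in place of hydroxy on an aromatic carbon and it is the only difference between the two.

Among the compounds with values here, no two measured compounds differ in one place, so the series offers no direct guide to this change. The expectation in this assay is therefore a step within the scatter with only a slight downward lean. The estimated change is a number 5 percentage points lower from compound 1 to compound 4 (within the scatter) and it would not be distinguishable from no change. The expected value for compound 4 is 47% with an estimated range from 30% to 63% for this measurement.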

Compound 4, percent growth inhibition at one concentration: 100%
Beside the measured number, compound 4's estimate is 53 percentage points below it; measured number above the stated range.
By their numbers in this assay, from the lowest: compound 2; then compounds 3 and 1 (each within the scatter of the next); then compound 4.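

In this assay, within the data shown here, the change from 4-hydroxyphenyl to 4-carbamoylphenyl gives a number 48 percentage points higher from compound 1 to compound 4 (beyond the scatter) and is the first single-place step available. This aromatic position, para to a large group, is therefore not indifferent to its substituent: carbamoyl in place of hydroxy alone moves growth inhibition beyond the scatter, and compound 4 reaches 100% at the one concentration tested. No measured evidence on these compounds accounts for the size of this step.

From the compounds shown here alone, it remains open whether the gain is specific to carbamoyl or would also appear with a carboxylic acid, a nitrile or an amine on the same aromatic carbon. A single-concentration read-out also leaves open how far compound 1 and compound 4 differ across a range of concentrations.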